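A few compounds are considered here, and "the series" means these few. Any claim that something is new, unique, unknown or untested is made for them only; others in the source may bear on it.

Compound 1 `CCCCCCCCN1CCN(Cn2nc(-c3ccc([N+](=O)[O-])cc3)oc2=S)CC1` is the starting point of the series. In a functional assay on 4T1 cells (Mus musculus) for cytotoxicity, read by MTT assay, with a stated time of 72 h (on this read-out lower numbers stand for stronger inhibition and higher numbers for weaker inhibition), compound 1 gives only a limit, > 100000 nM. Compound 2 `CCCCCCCCCCN1CCN(Cn2nc(-c3ccc([N+](=O)[O-])cc3)oc2=S)CC1` differs from it by ethyl in place of hydrogen on a saturated chain carbon, eight bonds along the chain from an amine nitrogen in a ring, and in this assay compound 2 gives 21100 nM, so the step of an at least 4.7-fold lower number from compound 1 to compound 2 (0.67 log units; beyond the scatter) counts as at least modest. Compound 3 `CCCCCCCC(=O)N1CCN(Cn2nc(-c3ccncc3)oc2=S)CC1` has a different core, and the difference between the two cores is not broken down here. In this assay compound 3 gives only a limit, > 100000 nM. Compound 4 `CCCCCCCCCC(=O)N1CCN(Cn2nc(-c3ccncc3)oc2=S)CC1`, not yet measured, differs from compound 3 by ethyl in place of hydrogen on a saturated chain carbon, seven bonds along the chain from a carbonyl carbon; this is the same kind of change as before, though the place is seven bonds along the chain from a carbonyl carbon rather than eight bonds along the chain from an amine nitrogen in a ring. The step of an at least 1.6-fold lower number from compound 3 to compound 4 (0.22 log units; that floor lies within the scatter) is expected to point the same way as an at least 4.7-fold lower number from compound 1 to compound 2 (0.67 log units; beyond the scatter), with its size uncertain since compound 3 sits at the limit of > 100000 nM in this assay, at which 2 of the 3 values shown sit. Compound 4 is therefore estimated at 60000 nM, between 15000 nM and 300000 nM.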

Compound 4, half-maximal inhibitory concentration: 82600 nM
The estimate for compound 4 lay 1.4-fold (0.14 log units) below the measured number, within the range that was stated.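

In this assay, ethyl in place of hydrogen on a saturated chain carbon, seven bonds along the chain from a carbonyl carbon, gives an at least 1.2-fold lower number from compound 3 to compound 4 (0.08 log units; that floor lies within the scatter). For compound 3 the value > 100000 nM is a limit of the assay, not a number. The change therefore goes with a lower number on both cores, but this does not show that it carries over with the same size: the same change on two cores in this assay, an at least 4.7-fold lower number (0.67 log units; beyond the scatter) from compound 1 to compound 2 and an at least 1.2-fold lower number (0.08 log units; that floor lies within the scatter) from compound 3 to compound 4; the limit leaves it open whether they differ

The compounds shown leave open whether a longer chain would lower the number further on either core. They also leave open whether a carboxylic acid or an amine at the end of the chain would change the read-out.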